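Shortening the Chain and Adding a Methyl: Compound 4

The source may report more compounds than this note shows. Statements on the series, on what has been measured and on what is new or still open speak of the compounds shown alone.

Compound 1 `O=S(=O)(NCCCNc1nccc(-c2c(-c3cccc(F)c3)nc3sccn23)n1)c1ccccc1` gives 6600 nM in a functional assay on A-375 cells (Homo sapiens) for cytotoxicity, read by MTT assay (a higher number here means a weaker inhibitor, a lower number a stronger inhibitor), the second highest number among the three measured compounds. Within the data shown here, compound 3 `O=S(=O)(NCCNc1nccc(-c2c(-c3cccc(F)c3)nc3sccn23)n1)c1ccc(C(F)(F)F)cc1` gives 7440 nM, within the scatter of compound 1, whereas compound 2 `O=C(NCCNc1nccc(-c2c(-c3cccc(F)c3)nc3sccn23)n1)c1ccc(Cl)cc1` gives 2570 nM, and the step of a 2.6-fold lower number from compound 1 to compound 2 (0.41 log units; beyond the scatter) is the only change that goes beyond the scatter. Compound 4 `Cc1ccc(S(=O)(=O)NCCNc2nccc(-c3c(-c4cccc(F)c4)nc4sccn34)n2)cc1` differs from compound 1 as follows: ((4-methylphenyl)sulfonyl)amino in place of ((phenylsulfonyl)amino)methyl on a saturated chain carbon, two bonds along the chain from a nitrogen on an aromatic ring. Among the measured compounds shown here, no measured step matches this change directly; the step from compound 1 to compound 2 also shortens the chain but exchanges the sulfonamide for an amide, and compound 3, carrying the shorter chain with a different ring substituent, sits close to compound 1. The step of a 1.1-fold lower number from compound 1 to compound 4 (0.04 log units; within the scatter) is therefore expected to stay within the scatter. Compound 4 is estimated at 6000 nM, with a range from 3000 nM to 12000 nM.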

Compound 4, half-maximal inhibitory concentration: 15400 nM
Compound 4: the middle estimate sits 2.6-fold (0.41 log units) below what was measured; the measured number lies above the stated range.
By their numbers in this assay, from the lowest: compound 2; then compounds 1 and 3 (each within the scatter of the next); then compound 4.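

Compound 1 and compound 4 hold the same atoms, joined differently, yet the step is a 2.3-fold higher number from compound 1 to compound 4 (0.37 log units; beyond the scatter) in this assay, so this position responds to how those atoms are arranged and not only to which atoms are present. The number also moves with each other single change: a 2.1-fold higher number from compound 3 to compound 4 (0.32 log units; beyond the scatter) for methyl in place of trifluoromethyl on an aromatic carbon, and a 6.0-fold higher number from compound 2 to compound 4 (0.78 log units; beyond the scatter) for (4-methylphenyl)sulfonyl in place of (4-chlorophenyl)carbonyl on an amine nitrogen. No evidence is at hand to account for these steps. Still open, as far as these compounds go, is how an amine or a carboxylic acid on that aromatic ring would read here.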